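This account rests on a few compounds, and the source may have more. Where it says the series, first, only, none or still open, it means among the compounds named here.

Of the compounds shown here, two have numbers so far in a functional assay on A549 cells (Homo sapiens) for antiproliferative activity, read by MTT assay, with a stated time of 48 h; a lower number here means a stronger inhibitor, a higher number a weaker inhibitor. Compound 1 `Cc1ccc(C(=O)/C=C/c2cccc(Cl)c2Oc2c([N+](=O)[O-])cc(C(F)(F)F)cc2[N+](=O)[O-])cc1` gives 0.95 ug/mL, while compound 2 `O=C(/C=C/c1cccc(Br)c1Oc1c([N+](=O)[O-])cc(C(F)(F)F)cc1[N+](=O)[O-])c1ccc(F)cc1` gives 26.3 ug/mL. That is the higher of the two numbers, so compound 2 is the weaker inhibitor of the pair, by a gap beyond the usual scatter.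

Compound 3 `O=C(/C=C/c1cccc(Cl)c1Oc1c([N+](=O)[O-])cc(C(F)(F)F)cc1[N+](=O)[O-])c1ccc(F)cc1` is still unmeasured. It is compound 2 with a single change, chloro in place of bromo on an aromatic carbon.

For the measured compounds named here, compounds 1 and 2 differ in more than one place, so no measured step shows what this swap does alone. Compound 3 shares the chloro of compound 1 at 0.95 ug/mL, but it keeps the 2-((4-fluorophenyl)carbonyl)ethenyl group of compound 2 at 26.3 ug/mL. A moderate move towards a lower number is therefore expected, and it may stay modest: the expected change is a 2.9-fold lower number from compound 2 to compound 3 (0.47 log units; beyond the scatter). For compound 3 the estimated value in this assay is 9 ug/mL, with a range of 2 ug/mL to 30 ug/mL.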

Compound 3, half-maximal inhibitory concentration: 23.8 ug/mL
Estimate against measurement, compound 3: 2.6-fold (0.42 log units) below; measured number inside the range.
By their numbers in this assay, from the lowest: compound 1; then compounds 3 and 2 (each within the scatter of the next).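

In this assay the swap of bromo for chloro at this aromatic carbon gives a 1.1-fold lower number from compound 2 to compound 3 (0.04 log units; within the scatter) and so, with the fluoro group in place, the two halogens cannot be told apart here. For the compounds shown here, the large difference lies at the other site, where fluoro in place of methyl on an aromatic carbon gives a 25-fold higher number from compound 1 to compound 3 (1.40 log units; beyond the scatter) and provides the first reading of that change on its own. No measurement on hand explains either result.

Whether chloro and bromo also match when methyl is present remains open, since compound 1 has no bromo partner among these compounds. Also open, going by these compounds, is how hydrogen or a methoxy group would compare at the halogen position, and how an amine would compare at the methyl and fluoro site.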